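Swapping an alkyne for an alkene on compound 1

The source may report more compounds than this note shows. Statements on the series, on what has been measured and on what is new or still open speak of the compounds shown alone.

Compound 1 `OC[C@H]1OC(n2cnc3c(C#Cc4ccccc4)ncnc32)[C@H](O)[C@@H]1O` was tested in a functional assay on K562 cells (Homo sapiens) for inhibition, read by thymidine incorporation, with a stated time of 48 h (a higher number here means a weaker inhibitor, a lower number a stronger inhibitor), where compound 1 gives 0.1 ug/mL. Among the three compounds measured, compound 1 has the lowest number: compound 3 `Nc1nc(/C=C/c2ccccc2)c2ncn(Cc3ccccc3)c2n1` gives 1.2 ug/mL, and compound 2 `Clc1nc(/C=C/c2ccccc2)c2ncn(Cc3ccccc3)c2n1` gives 2 ug/mL. Among the compounds with values here, the one step available between measured compounds, a 1.7-fold lower number from compound 2 to compound 3 (0.22 log units; within the scatter), concerns an amino in place of chloro on a different core and says nothing about the change considered here.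

Compound 4 `OC[C@H]1OC(n2cnc3c(/C=C/c4ccccc4)ncnc32)[C@H](O)[C@@H]1O` differs from compound 1 in one place: 2-phenylethenyl in place of 2-phenylethynyl on an aromatic carbon. Within the data shown here, the 2-phenylethenyl group already appears in compounds 2 and 3, but there it sits on another core, so no measured step shows what exchanging 2-phenylethynyl for 2-phenylethenyl does on the core of compound 1. With no direct evidence, the change is expected to stay small, with some chance of a weaker result. Compound 4 is therefore estimated at 0.3 ug/mL, between 0.08 ug/mL and 1.2 ug/mL, an expected step of a 3.0-fold higher number from compound 1 to compound 4 (0.48 log units; beyond the scatter).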

Compound 4, half-maximal inhibitory concentration: 2 ug/mL
Beside the measured number, compound 4's estimate is 6.7-fold (0.82 log units) below it, outside the stated range (above it).
By their numbers in this assay, from the lowest: compound 1; then compounds 3, 2 and 4 (each within the scatter of the next).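

There is a large step of a 20-fold higher number from compound 1 to compound 4 (1.30 log units; beyond the scatter) in this assay when 2-phenylethenyl replaces 2-phenylethynyl on this aromatic carbon of the core of compound 1. The group leaving and the group entering differ only in a triple bond outside the aromatic ring against a double bond, so on this core a change that small is enough to give a step well beyond the scatter. Nothing available accounts for the weaker result with the double bond.

The compounds shown leave open whether the same exchange would give a step of similar size on the core of compounds 2 and 3. They also leave open how a 2-phenylethyl group, with a single bond in place of the triple or double bond, or a plain amine on this aromatic carbon would compare.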